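The source may hold more compounds than are shown below. What is called first, only, known or untested is meant among the compounds shown, and "the series" means these compounds.

Measured so far in an ADME assay on BJ cells (Homo sapiens) for inhibition, with a stated time of 72 h; on this read-out higher numbers stand for an effect only at larger amounts of compound and lower numbers for an effect already at smaller amounts:
compound 1 `C=C(C)C(=O)Nc1cccc(-c2nc3ccccc3s2)c1`, giving > 25000 nM, which is a limit of the assay.
compound 2 `CC(Cl)C(=O)Nc1cccc(-c2nc3ccccc3s2)c1`, giving > 25000 nM, which is a limit of the assay.
compound 3 `O=C(Nc1cccc(-c2nc3ccccc3s2)c1)c1ccc(Cl)nc1Cl`, giving > 25000 nM, which is a limit of the assay.

Compound 3 therefore stands only at a limit, and all three values sit together at the limit of > 25000 nM in this assay, at which 3 of the 3 values shown sit. Compound 4 `O=C(Nc1cccc(-c2nc3ccccc3s2)c1)c1cnc(Cl)s1` differs from compound 3 by 2-chloro-1,3-thiazol-5-yl in place of 2,6-dichloropyridin-3-yl on a carbonyl carbon. Among the compounds with values here, the steps that bear on a change at this carbonyl carbon are a step that the two limits leave unreadable from compound 1 to compound 3, a step that the two limits leave unreadable from compound 2 to compound 3 and a step that the two limits leave unreadable from compound 1 to compound 2; none has a readable size, as both ends of each lie at the limit. No step beyond the scatter can be read from them, and none is expected in this assay. Compound 4 is estimated at 30000 nM, with a range from 10000 nM to 100000 nM. The expected step is a step that the limit leaves unreadable from compound 3 to compound 4, most likely again reported only as a limit.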

Compound 4, half-maximal effective concentration: > 25000 nM
Compound 4 was reported as a limit; the forecaster's own chance of this, stated with the estimate: 80%; the middle value is on the limit's open side.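

No step can be read among compound 1, compound 2, compound 3 and compound 4 in this assay, as each value is only a limit: the limit of > 25000 nM in this assay, at which 4 of the 4 values shown sit. The compounds shown leave open how these four compare in this assay and whether any change on the carbonyl carbon alters the read-out.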